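Swapping furan for thiophene on two related aryl ketone cores

The source may report more compounds than this note shows. Statements on the series, on what has been measured and on what is new or still open speak of the compounds shown alone.

Of the compounds shown here, three have been tested in a functional assay on T47D cells (Homo sapiens) for inhibition, read by CCK-8 assay and cell counting, with a stated time of 2 days; on this read-out higher numbers stand for weaker inhibition and lower numbers for stronger inhibition. Compound 1 `O=C(/C=C/c1ccco1)c1ccccc1OCC1CO1` gives 19400 nM. Compound 2 `O=C(/C=C/c1cccs1)c1ccccc1OCC1CO1` gives 17700 nM. Compound 3 `O=C(/C=C/c1ccco1)c1cccc(OCC2CO2)c1` gives 22700 nM, and each of its gaps to the other two numbers lies within the usual scatter of the measurement. Within the data shown here, the one counted step among them is a 1.1-fold lower number from compound 1 to compound 2 (0.04 log units; within the scatter); the change behind it is thiophen-2-yl in place of furan-2-yl on a double-bonded chain carbon bound to a double-bonded chain carbon. Compound 3 is built from the same atoms as compound 1 joined differently, and the difference between the two cores is not broken down here.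

Compound 4 `O=C(/C=C/c1cccs1)c1cccc(OCC2CO2)c1` has not yet been measured. It arises from compound 3 by the same change that turns compound 1 into compound 2, namely (thiophen-2-yl in place of furan-2-yl on a double-bonded chain carbon bound to a double-bonded chain carbon). For compound 4 the step from its parent is estimated as a 1.1-fold lower number from compound 3 to compound 4 (0.03 log units; within the scatter), because a 1.1-fold lower number from compound 1 to compound 2 (0.04 log units; within the scatter) already showed this change to stay within the scatter on the core of compound 1. Compound 4 is therefore expected to give about 21000 nM in this assay, most likely between 12000 nM and 38000 nM.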

Compound 4, half-maximal inhibitory concentration: 14600 nM
Estimate against measurement, compound 4: 1.4-fold (0.16 log units) above, and the stated range covers the measured number.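

In this assay, putting thiophen-2-yl in place of furan-2-yl on the second core gives a 1.6-fold lower number from compound 3 to compound 4 (0.19 log units; within the scatter), so the change again stays within the scatter. Set beside the earlier step, the change shows no measurable dependence on which of the two cores carries it: the same change on two cores in this assay, a 1.1-fold lower number (0.04 log units; within the scatter) from compound 1 to compound 2 and a 1.6-fold lower number (0.19 log units; within the scatter) from compound 3 to compound 4, 1.4-fold (0.15 log units) apart, within the scatter of two such steps This supports carrying the change between these two cores without expecting a clear shift in the number, but it does not show that thiophen-2-yl truly outperforms furan-2-yl or that the two steps are identical, and two cores are too few to support a rule for other cores.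

Both steps exchange one five-membered aromatic ring with one hetero atom for another, so the compounds shown leave open how a six-membered ring such as pyridin-2-yl would read in the same place. They also leave open whether an amine or a carboxylic acid on the ring would move the number beyond the scatter.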